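Chloro to dimethyl on the amide aryl of a chromone acrylamide

This account rests on a few compounds, and the source may have more. Where it says the series, first, only, none or still open, it means among the compounds named here.

Measured so far:
compound 1 `COc1ccc2c(=O)c(/C=C/C(=O)Nc3cccc(Cl)c3)coc2c1` 470 nM
compound 2 `COc1ccc2c(=O)c(/C=C/C(=O)Nc3ccccc3Cl)coc2c1` 29900 nM

In a functional assay on A549 cells (Homo sapiens) for inhibition, read by MTT assay, with a stated time of 48 h (a lower number here means a stronger inhibitor, a higher number a weaker inhibitor), compound 2 gives the higher of the two numbers; its nearest neighbour is compound 1, and the step of a 64-fold higher number from compound 1 to compound 2 (1.80 log units; beyond the scatter) was large. Compound 3 `COc1ccc2c(=O)c(/C=C/C(=O)Nc3cc(C)ccc3C)coc2c1` differs from compound 2 by 2,5-dimethylphenyl in place of 2-chlorophenyl on an amide-type nitrogen. Going by the values given here, only one measured step bears on this change, a 64-fold higher number from compound 1 to compound 2 (1.80 log units; beyond the scatter), and it concerns a chlorine position rather than a methyl for chlorine exchange, so it gives limited guidance. Compound 3 keeps a substituent at the 2-position, and is therefore expected to remain weak, with a step of a 2.0-fold lower number from compound 2 to compound 3 (0.30 log units; within the scatter) in this assay. Compound 3 is estimated at 15000 nM, with a range from 3000 nM to 60000 nM.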

Compound 3, half-maximal inhibitory concentration: 15500 nM
Compound 3: the middle estimate sits 1.0-fold (0.01 log units) below what was measured, within the range that was stated.
By their numbers in this assay, from the lowest: compound 1; then compounds 3 and 2 (each within the scatter of the next).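

In this assay, 2,5-dimethylphenyl in place of 2-chlorophenyl on the amide-type nitrogen gives no change beyond the scatter (a 1.9-fold lower number from compound 2 to compound 3 (0.29 log units; within the scatter)), so this exchange of chlorine for two methyl groups does not separate the two compounds. Set against the 3-chlorophenyl group, the same 2,5-dimethylphenyl group gives a large step (a 33-fold higher number from compound 1 to compound 3 (1.52 log units; beyond the scatter)), so compound 1 now stands apart from two differently substituted aryl groups rather than one. Nothing measured here accounts for these steps.

Going by these compounds, whether an amine or a carboxylic acid on this phenyl ring would give a number near that of compound 1 stays open. Also open, on these data alone, is how a plain unsubstituted phenyl group would compare with all three.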